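A few compounds are considered here, and "the series" means these few. Any claim that something is new, unique, unknown or untested is made for them only; others in the source may bear on it.

Among the compounds with values here, compound 2, `COc1cncc(C(=O)NC2(C(=O)N[C@H](C)c3ccc(-n4nc(Cl)c5ccccc54)cc3F)CC2)c1`, is one of two compounds measured in an in vivo ADME assay on the whole organism (strain Mongrel) for pharmacokinetics, with Canis familiaris (Canis lupus familiaris) as the target (on this read-out lower numbers stand for slow clearance and higher numbers for fast clearance), and compound 2 gives 5.5 mL/min/kg, the higher of the two numbers. Its partner compound 1, `C[C@@H](NC(=O)C1(NC(=O)c2ccc(Br)nc2)CC1)c1ccc(-n2nc(Cl)c3ccccc32)cc1F`, gives 2.6 mL/min/kg in this assay. Within the data shown here, the one measured step, a 2.1-fold higher number from compound 1 to compound 2 (0.33 log units; beyond the scatter), came with 5-methoxypyridin-3-yl in place of 6-bromopyridin-3-yl on a carbonyl carbon. Compound 3, `C[C@@H](NC(=O)C1(NC(=O)c2cncc(Br)c2)CC1)c1ccc(-n2nc(Cl)c3ccccc32)cc1F`, has not yet been measured; it differs from compound 2 in one place: bromo in place of methoxy on an aromatic carbon. So a bromine returns, though compound 3 carries 5-bromopyridin-3-yl where compound 1 carried 6-bromopyridin-3-yl, and no measured pair shows that exact swap. Because a 2.1-fold higher number from compound 1 to compound 2 (0.33 log units; beyond the scatter) ran upward when methoxy replaced bromine, a modest step back downward is expected, as a 1.6-fold lower number from compound 2 to compound 3 (0.20 log units; within the scatter), though with some doubt. Compound 3 is therefore estimated at 3.5 mL/min/kg in this assay, within 1.8 mL/min/kg to 6.5 mL/min/kg.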

Compound 3, clearance: 3.8 mL/min/kg
Beside the measured number, compound 3's estimate is 1.1-fold (0.04 log units) below it; low and high end bracket the measured number.
By their numbers in this assay, from the lowest: compounds 1, 3 and 2 (each within the scatter of the next, the first and the last beyond it).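

Taken alone, bromo in place of methoxy on this aromatic carbon gives a 1.4-fold lower number from compound 2 to compound 3 (0.16 log units; within the scatter), so in this assay these two groups cannot be told apart at this place on the ring. Moving the bromine, with 5-bromopyridin-3-yl in place of 6-bromopyridin-3-yl, gives a 1.5-fold higher number from compound 1 to compound 3 (0.16 log units; within the scatter), so neither smaller change clears the scatter, although a 2.1-fold higher number from compound 1 to compound 2 (0.33 log units; beyond the scatter) does when the group and its place on the ring differ together. Nothing measured here explains these clearance numbers. As far as these compounds go, it remains open whether an amine or a carboxylic acid on the same ring carbon would shift clearance beyond the scatter. Also open, from the compounds shown here alone, is whether methoxy at the place held by bromine in compound 1 would separate the effect of the group from that of its position.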